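This account rests on a few compounds, and the source may have more. Where it says the series, first, only, none or still open, it means among the compounds named here.

In a functional assay on PC-3 cells (Homo sapiens) for cytotoxicity, read by MTT assay, with a stated time of 72 h (a lower number here means a stronger inhibitor, a higher number a weaker inhibitor), compound 1 `COc1cc2ncnc(Nc3ccc(F)c(Cl)c3)c2cc1NC(=O)N/N=C/c1ccc(O)c(Br)c1` gives 15300 nM and compound 2 `COc1cc2ncnc(Nc3ccc(F)c(Cl)c3)c2cc1NC(=O)N/N=C/c1ccc(O)cc1O` gives 29500 nM, two values within the scatter of each other. Compound 3 `CCN(CC)c1ccc(/C=N/NC(=O)Nc2cc3c(Nc4ccc(F)c(Cl)c4)ncnc3cc2OC)c(O)c1` keeps the shared core and alters one group of compound 2: diethylamino in place of hydroxy on an aromatic carbon. Among the compounds with values here, the only measured step, a 1.9-fold higher number from compound 1 to compound 2 (0.29 log units; within the scatter), exchanged 3-bromo-4-hydroxyphenyl for 2,4-dihydroxyphenyl and stayed within the scatter. This single step is thin evidence, so no step beyond the scatter, in either direction, is expected. The expected step is a 1.3-fold lower number from compound 2 to compound 3 (0.13 log units; within the scatter). For compound 3 the estimated value is 22000 nM, with an expected range of 8000 nM to 60000 nM.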

Compound 3, half-maximal inhibitory concentration: 34300 nM
Estimate against measurement, compound 3: 1.6-fold (0.19 log units) below, within the range that was stated.
By their numbers in this assay, from the lowest: compounds 1, 2 and 3 (each within the scatter of the next, the first and the last beyond it).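

In this assay, diethylamino in place of hydroxy on this aromatic carbon gives a 1.2-fold higher number from compound 2 to compound 3 (0.07 log units; within the scatter), so a group of five heavy atoms with no hydrogen-bond donor can stand here without a step that can be read. Within the data shown here, the wider exchange of the whole aryl group gives a 2.2-fold higher number from compound 1 to compound 3 (0.35 log units; beyond the scatter), the only step beyond the scatter here, and a modest one. Nothing measured here gives a reason for either step. Going by these compounds, whether a primary amine, a carboxylic acid or a longer alkoxy chain at this position would give a clearer step remains open.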